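The source may hold more compounds than are shown below. What is called first, only, known or untested is meant among the compounds shown, and "the series" means these compounds.

Measured compounds:
compound 1 `COc1cc(NC(C)CCCNC(=O)Nc2cccc(Cl)c2)c2ncccc2c1` gives 22000 nM in a functional assay on CCRF-CEM cells (Homo sapiens) for inhibition, read by MTT assay, with a stated time of 72 h; a lower number here means a stronger inhibitor, a higher number a weaker inhibitor
compound 2 `COc1cc(NC(C)CCCNC(=O)NNC(=O)Nc2ccc(F)cc2)c2ncccc2c1` gives 118000 nM
compound 3 `COc1cc(NC(C)CCCNC(=O)NNC(=O)Nc2cccc(C(F)(F)F)c2)c2ncccc2c1` gives 6900 nM

Compound 2 stands at the highest number of the three in this assay, with compound 1 nearest to it and compound 3 furthest. Compound 4 `COc1cc(NC(C)CCCNC(=O)NNC(=O)Nc2ccc(O)cc2)c2ncccc2c1` differs from compound 2 by hydroxy in place of fluoro on an aromatic carbon. Neither measured step changes the same position of the same ring: the step of a 5.4-fold higher number from compound 1 to compound 2 (0.73 log units; beyond the scatter) alters the whole linker and aryl group, and the step of a 17-fold lower number from compound 2 to compound 3 (1.23 log units; beyond the scatter) moves from a para substituent to a meta one. Both show that this aryl group matters, so compound 4 is expected to shift somewhat from compound 2, with a 1.2-fold lower number from compound 2 to compound 4 (0.07 log units; within the scatter), most likely within or just beyond the scatter. Compound 4 is expected near 100000 nM, between 30000 nM and 300000 nM.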

Compound 4, half-maximal inhibitory concentration: 111000 nM
The estimate for compound 4 lay 1.1-fold (0.05 log units) below the measured number; the range from low to high includes it.
By their numbers in this assay, from the lowest: compound 3; then compound 1; then compounds 4 and 2 (each within the scatter of the next).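

In this assay, hydroxy in place of fluoro on this aromatic carbon, para to a large group, barely registers: a 1.1-fold lower number from compound 2 to compound 4 (0.03 log units; within the scatter). Adding a hydrogen-bond donor and acceptor here therefore leaves the number where it was, and compound 4 stays on the weak side of the series, with a 16-fold higher number from compound 3 to compound 4 (1.21 log units; beyond the scatter) and a 5.0-fold higher number from compound 1 to compound 4 (0.70 log units; beyond the scatter). Nothing available accounts for this insensitivity. From the compounds shown here alone, it remains open whether an amine or a carboxylic acid on this carbon would also leave the number in place. Also open, going by these compounds, is whether the much lower number of compound 3 belongs to trifluoromethyl itself or to where it sits on the ring.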